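The source may report more compounds than this note shows. Statements on the series, on what has been measured and on what is new or still open speak of the compounds shown alone.

Measured compounds:
- compound 1, `COc1cccc(CN(C(=O)c2ccccc2)[C@H](C)C(N)=O)c1`: in an assay on HEK293 cells for antagonist activity at transient receptor potential cation channel subfamily M member 8 (Homo sapiens), read by calcium flux (on this read-out higher numbers stand for weaker inhibition and lower numbers for stronger inhibition), compound 1 gives > 100000 nM, a limit of the assay.
- compound 2, `COC(=O)[C@@H](c1ccccc1)N(Cc1cccc(OC)c1)C(=O)c1ccccc1`: in this assay compound 2 gives 210 nM.

For the measured compounds named here, compound 2 holds the only numeric value in this assay so far; the other value is a limit, (the limit of > 100000 nM in this assay, at which 1 of the 2 values shown sits), so no step between measured compounds can be stated, and the two values show only that compound 2 inhibits while compound 1 does not within the range of the assay.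

Compound 3, `CNC(=O)[C@@H](c1ccccc1)N(Cc1cccc(OC)c1)C(=O)c1ccccc1`, is not yet measured. It differs from compound 2 in one place: methylamino in place of methoxy on a carbonyl carbon, the methoxycarbonyl of compound 2 becoming a methylcarbamoyl. With no measured step of this kind in the series, the expectation rests on compound 2 alone. The expected step of a 2.4-fold higher number from compound 2 to compound 3 (0.38 log units; beyond the scatter) is toward somewhat weaker inhibition, modest in size and possibly no larger than the scatter. For compound 3 the estimate in this assay is 500 nM, with a range from 150 nM to 2500 nM.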

Compound 3, half-maximal inhibitory concentration: 10000 nM
Compound 3: the middle estimate sits 20-fold (1.30 log units) below what was measured; the measured number lies above the stated range.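

In this assay, for the compounds shown here, methylamino in place of methoxy on a carbonyl carbon gives a 48-fold higher number from compound 2 to compound 3 (1.68 log units; beyond the scatter), the first measured step, and it shows that inhibition is sensitive to this position. The change is small by count: 2 heavy atoms leave and 2 heavy atoms enter, with no ring and no net charge involved, while 1 hydrogen-bond acceptor leaves and 1 hydrogen-bond donor enters. The values shown offer no measured basis for explaining the size of this step.

Going by these compounds, it remains open whether the weaker inhibition follows the amide hydrogen or the change from methoxycarbonyl to methylcarbamoyl as a whole: a dimethylamino group on the same carbonyl carbon, which carries no amide hydrogen, would separate the two readings. Equally open, on these data alone, is how an ethoxy group or the free carboxylic acid in that place would read in this assay, and so how narrow the requirement at this carbonyl carbon really is.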